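The source may hold more compounds than are shown below. What is called first, only, known or untested is meant among the compounds shown, and "the series" means these compounds.

Measured in an ADME assay on microsomes from liver (Rattus norvegicus), read by LC-MS, using NADPH, with a stated time of 10 min, tested at 0.5 uM; a lower number here means that less of the compound is left, a higher number that more of the compound is left:
compound 1 `Cc1nc2cc(-c3cccc(-c4ccccc4)c3)nn2c(-c2cc(F)c3c(c2C)CCCO3)c1[C@H](OC(C)(C)C)C(=O)O`: 96%
compound 2 `Cc1ccccc1-c1cccc(-c2cc3nc(C)c([C@H](OC(C)(C)C)C(=O)O)c(-c4cc(F)c5c(c4C)CCCO5)n3n2)c1`: 97%
compound 3 `Cc1nc2cc(-c3cccc(-c4ccncc4)c3)nn2c(-c2cc(F)c3c(c2C)CCCO3)c1[C@H](OC(C)(C)C)C(=O)O`: 94%

The three compounds share one core and differ in a single aromatic group. Compound 3 stands level with the other two, as the steps show: a number 2 percentage points lower from compound 1 to compound 3 (within the scatter) and a number 3 percentage points lower from compound 2 to compound 3 (within the scatter).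

Compound 4 `COc1ccc(-c2cccc(-c3cc4nc(C)c([C@H](OC(C)(C)C)C(=O)O)c(-c5cc(F)c6c(c5C)CCCO6)n4n3)c2)cn1` keeps the shared core and has 6-methoxypyridin-3-yl in place of pyridin-4-yl on an aromatic carbon.

Among the measured compounds shown here, the steps that bear on this change are the exchanges of the same aromatic group, namely those above and a number 1 percentage points higher from compound 1 to compound 2 (within the scatter). None of them leaves the scatter, so no step beyond the scatter is expected in this assay. For the measured compounds named here, no measured compound carries a methoxy group, however, so the range is kept wider on the lower side.

The estimated step is a number 2 percentage points lower from compound 3 to compound 4 (within the scatter).

For compound 4 the expected value is 92%, with an estimated range from 80% to 99%.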

Compound 4, percent of the compound remaining: 100%
Beside the measured number, compound 4's estimate is 8 percentage points below it; the whole stated range lies below it.
By their numbers in this assay, from the lowest: compounds 3, 1, 2 and 4 (each within the scatter of the next).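

Among the compounds shown here, compound 4 shows that 6-methoxypyridin-3-yl, the only group here that carries a methoxy group, fits this place on the ring without moving the read-out of this assay beyond the scatter, with a number 6 percentage points higher from compound 3 to compound 4 (within the scatter) and a number 3 percentage points higher from compound 2 to compound 4 (within the scatter) and a number 4 percentage points higher from compound 1 to compound 4 (within the scatter) all printed as within it. For the compounds shown here, the methoxy group thus adds no visible loss of compound in this assay, and across all four compounds the group at this place makes no difference that can be read. Nothing measured here gives a reason for this level result.

On these data alone, all four groups compared are six-membered aromatic rings, so it stays open whether an amine such as morpholine or a longer alkoxy chain at this place would keep the read-out in the same range. As far as these compounds go, it also stays open whether a methoxy group elsewhere on the pyridine would do the same.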